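Aryl ether swap on the amide side chain

A few compounds are considered here, and "the series" means these few. Any claim that something is new, unique, unknown or untested is made for them only; others in the source may bear on it.

As far as these compounds go, compound 3 `CCc1ccc(OCC(=O)Nc2ccc(OCC(=O)O)c(F)c2)cc1` carries a 4-ethylphenyl group; in a functional assay on CHO cells for agonist activity at Free fatty acid receptor 1 (Homo sapiens), read by FLIPR (on this read-out higher numbers stand for an effect only at larger amounts of compound and lower numbers for an effect already at smaller amounts), compound 3 has "not determined" (no result reported), so its position is unknown. Its neighbours are measured: compound 1 `Cc1cccc(OCC(=O)Nc2ccc(OCC(=O)O)c(F)c2)c1` gives 108 nM and compound 2 `Cc1ccc(OCC(=O)Nc2ccc(OCC(=O)O)c(F)c2)cc1` gives 148 nM, and the step of a 1.4-fold higher number from compound 1 to compound 2 (0.14 log units; within the scatter) shows that moving a methyl group around this ring leaves the read-out essentially unchanged. Compound 4 `COc1cccc(OCC(=O)Nc2ccc(OCC(=O)O)c(F)c2)c1` arises from compound 3 by the change (3-methoxyphenyl in place of 4-ethylphenyl on an oxygen on a saturated carbon). Among the measured compounds shown here, no measured step covers this exact exchange, and the only related step is the one within the scatter, so no shift beyond the scatter is expected. Compound 4 is therefore estimated at 120 nM, with a range from 40 nM to 400 nM.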

Compound 4, half-maximal effective concentration: 148 nM
Compound 4: the middle estimate sits 1.2-fold (0.09 log units) below what was measured; the measured number falls inside the stated range.
By their numbers in this assay, from the lowest: compounds 1, 2 and 4 (each within the scatter of the next).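

In this assay the methoxy group in place of methyl on an aromatic carbon gives a 1.4-fold higher number from compound 1 to compound 4 (0.14 log units; within the scatter) and the change to 3-methoxyphenyl from 4-methylphenyl gives no change at the digits printed from compound 2 to compound 4 (within the scatter) here. So a ring substituent joined through oxygen, with the one hydrogen-bond acceptor it adds, sits at this place as well as a plain methyl, with no step beyond the scatter. Nothing at hand explains why the read-out stays this flat.

As far as these compounds go, whether an amine, a trifluoromethyl group or a longer chain on this ring would move the number beyond the scatter stays open. With no number for compound 3, the 4-ethylphenyl group cannot yet be compared with the others.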